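Compound 1 without its 4-methylpiperazin-1-yl group

The compounds below may be only part of what the source reports. "The series", "measured", "known", "first", "only" and "open" are said of these compounds alone.

In a functional assay on HT-1080 cells (Homo sapiens) for cytotoxicity, read by MTT assay, with a stated time of 72 h (on this read-out higher numbers stand for weaker inhibition and lower numbers for stronger inhibition), compound 1 (`COc1ccc(Cn2cc3cc(C(=N)Nc4ccc(N5CCN(C)CC5)cc4)ncc3n2)cc1`) gives 3200 nM, the middle of three numbers. Compound 3 (`COc1ccc(Cn2nc(-c3ccccc3)c3cc(C(=N)Nc4ccc(N5CCN(C)CC5)cc4)nc(Nc4cc(OC)c(OC)c(OC)c4)c32)cc1`) lies lower at 1200 nM, and compound 2 (`CN1CCN(c2ccc(NC(=N)c3cc4cn(C)nc4cn3)cc2)CC1`) lies higher at 21000 nM.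

Compound 4 (`COc1ccc(Cn2cc3cc(C(=N)Nc4ccccc4)ncc3n2)cc1`) has hydrogen in place of 4-methylpiperazin-1-yl on an aromatic carbon. Within the data shown here, no measured step covers this place. The nearest guide is a 6.6-fold higher number from compound 1 to compound 2 (0.82 log units; beyond the scatter), where a different group gave way to hydrogen and the number rose. That single case gives only a rough guide to size and direction. The step expected in this assay is similarly modest and upward: a 2.2-fold higher number from compound 1 to compound 4 (0.34 log units; beyond the scatter). The estimate for compound 4 is 7000 nM, with an expected range of 2000 nM to 25000 nM.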

Compound 4, half-maximal inhibitory concentration: 1130 nM
Estimate against measurement, compound 4: 6.2-fold (0.79 log units) above; the measured number lies below the stated range.
By their numbers in this assay, from the lowest: compounds 4 and 3 (each within the scatter of the next); then compound 1; then compound 2.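

In this assay, hydrogen in place of 4-methylpiperazin-1-yl gives a 2.8-fold lower number from compound 1 to compound 4 (0.45 log units; beyond the scatter), so the lower number at this aromatic carbon does not depend on that group. All earlier compounds carried the group, and this step runs opposite in direction to the other single-place removal, a 6.6-fold higher number from compound 1 to compound 2 (0.82 log units; beyond the scatter), where 4-methoxyphenyl gave way to hydrogen. No measured evidence bears on the reason for the drop.

On these data alone, whether a morpholine or a dimethylamino group on the same carbon would keep this step stays open. Also open, as far as these compounds go, is whether the same removal behaves alike on the core of compound 3.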